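This account rests on a few compounds, and the source may have more. Where it says the series, first, only, none or still open, it means among the compounds named here.

The measured compounds:

Compound 1, `COc1ccc(Nc2cccc3c2C(=O)N(C2CCC(=O)NC2=O)C3=O)cc1`, giving 13% in an assay on FRT-Jurkat cells for inhibition of nuclear factor NF-kappa-B complex (Homo sapiens), read by flow cytometry, with a stated time of 24 h, tested at 10 uM; on this read-out higher numbers stand for more inhibition at the one concentration tested (going by the name of the read-out) and lower numbers for less inhibition.
Compound 2, `Cc1ccc(Nc2ccc3c(c2)C(=O)N(C2CCC(=O)NC2=O)C3=O)cc1`, giving 5% in this assay.
Compound 3, `CCCCCc1ccc(Nc2ccc3c(c2)C(=O)N(C2CCC(=O)NC2=O)C3=O)cc1`, giving 12% in this assay.

All three share one core, differing only in the substituent on the aniline ring and in where the anilino group joins the core. Compound 1 sits together with compound 3 and compound 2 within the usual scatter, so the three numbers cannot be ordered. Among the compounds with values here, the single measured step, a number 7 percentage points higher from compound 2 to compound 3 (within the scatter), concerns a saturated chain carbon and is itself within the scatter.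

Compound 4, `C=C(OCC)c1ccc(Nc2cccc3c2C(=O)N(C2CCC(=O)NC2=O)C3=O)cc1`, arises from compound 1 by the change (1-ethoxyethenyl in place of methoxy on an aromatic carbon). The entering group carries a double bond outside aromatic rings and sits para to a large group. Within the data shown here, no measured step touches this position or this kind of group, so nothing in the data points to a change in either direction beyond the scatter; the step from compound 2 to compound 3 is the only comparison and it was flat.

Compound 4 is therefore expected to give about 12% in this assay, between 0% and 28%. The expected step is a number 1 percentage points lower from compound 1 to compound 4 (within the scatter).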

Compound 4, a percentage reported as inhibition, at one concentration (the size of the read-out at that concentration, not a potency): 10%
Compound 4: middle estimate off by 2 percentage points, on the high side, within the range that was stated.
By their numbers in this assay, from the lowest: compounds 2, 4, 3 and 1 (each within the scatter of the next).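

At the aromatic carbon para to a large group, 1-ethoxyethenyl in place of methoxy gives a number 3 percentage points lower from compound 1 to compound 4 (within the scatter) in this assay, the first step measured at this position. A group of 5 heavy atoms with a double bond outside aromatic rings, entering for one of 2 heavy atoms, therefore leaves the read-out within the scatter of the methoxy compound. No measurement shown bears on why this step stays so small.

From the compounds shown here alone, whether an amine or a carboxylic acid on this aromatic carbon would move the number beyond the scatter remains open. Also open, going by these compounds, is whether 1-ethoxyethenyl would give a similar result on the aniline ring of compound 2, where the anilino group joins the core at a different place.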